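Changing One Group on a Shared Core

The compounds below may be only part of what the source reports. "The series", "measured", "known", "first", "only" and "open" are said of these compounds alone.

Values in an ADME assay on CEM-SS cells (Homo sapiens) for cytotoxicity, read by XTT assay, with a stated time of 6 days (on this read-out higher numbers stand for lower toxicity in this test and lower numbers for higher toxicity in this test), so far:
- Compound 1 `CCCC(=O)OCSc1ccccc1C(=O)NCCCCCCC(N)=O` gives 10.4 uM here
- Compound 2 `CCCC(=O)OCSc1ccccc1C(=O)N[C@H]1CCC[C@H]1C(N)=O` gives 89.9 uM; 84.8 uM (2 entries) here
- Compound 3 `CCCC(=O)OCSc1ccccc1C(=O)OCC(N)=O` gives 82.1 uM here

Compound 3 (82.1 uM) sits far from compound 1 (10.4 uM), a gap beyond the scatter, and level with compound 2 (89.9 uM; 84.8 uM (2 entries)). Compound 4 `CCCC(=O)OCSc1ccccc1C(=O)NCC(=O)OC` awaits measurement. It differs from compound 3 (((methoxycarbonyl)methyl)amino in place of carbamoylmethoxy on a carbonyl carbon) by having ((methoxycarbonyl)methyl)amino in place of carbamoylmethoxy on a carbonyl carbon. Neither group has a ring or a net charge, and no measured step sizes this swap, so compound 3 (82.1 uM) serves as the starting point. The expected change is small and downward, within the scatter (a 1.4-fold lower number from compound 3 to compound 4 (0.14 log units; within the scatter)). Compound 4 is estimated at 60 uM (expected range 20 uM to 130 uM).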

Compound 4, half-maximal toxic concentration: 27.3 uM
Estimate against measurement, compound 4: 2.2-fold (0.34 log units) above; measured number inside the range.
By their numbers in this assay, from the lowest: compound 1; then compound 4; then compound 3.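

In this assay, putting ((methoxycarbonyl)methyl)amino in place of carbamoylmethoxy on this carbonyl carbon gives a 3.0-fold lower number from compound 3 to compound 4 (0.48 log units; beyond the scatter), so the position responds even to a swap with no change in rings, net charge, or hydrogen-bond donors and acceptors. With methoxycarbonyl in place of 5-carbamoylpentyl, the same amide-linked position shows a 2.6-fold higher number from compound 1 to compound 4 (0.42 log units; beyond the scatter), placing compound 4 between compound 1 and compound 3. Nothing measured here explains either shift. The swap from compound 3 changes both the linking atom and the chain end, and the compounds shown do not separate those two changes. On these data alone, how a carboxylic acid in place of methoxycarbonyl would read remains open.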